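A few compounds are considered here, and "the series" means these few. Any claim that something is new, unique, unknown or untested is made for them only; others in the source may bear on it.

Series notes, inhibition of lung-cancer cell growth.

Compound 1 `CN(C)C(=O)c1cc2cnc(Nc3ccc(S(=O)(=O)NCCCN=C=S)cc3)nc2n1C1CCCC1` gives 41.3% in a functional assay on NCI-H1299 cells (Homo sapiens) for inhibition, read by CCK-8 assay, with a stated time of 72 h, tested at 1 uM; a lower number here means a weaker effect, a higher number a stronger effect of the compound at the concentration tested. For the measured compounds named here, that number stands at the top of the three measured so far, with compound 2 within the scatter of it and compound 3 beyond it. Compound 2 `CN(C)C(=O)c1cc2cnc(Nc3ccc(C(=O)NCCCCCN=C=S)cc3F)nc2n1C1CCCC1`, which carries a fluorine and an amide-linked isothiocyanate chain in place of the sulfonamide-linked chain, gives 36.1% in this assay. Going by the values given here, compound 3 `CN(C)C(=O)c1cc2cnc(Nc3ccc(C(=O)NCCCCCCN=C=S)cc3F)nc2n1C1CCCC1` extends that chain and gives 29.1% in this assay; the only measured step, a number 7 percentage points lower from compound 2 to compound 3 (within the scatter), shows that adding one chain carbon does not move the read-out beyond the scatter.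

Compound 4 `CN(C)C(=O)c1cc2cnc(Nc3ccc(NC(=O)CCCCCN=C=S)cc3)nc2n1C1CCCC1` differs from compound 1 by a group of 11 heavy atoms (7 carbon, 2 nitrogen, 1 oxygen, 1 sulfur; no ring) in place of a group of 10 heavy atoms (4 carbon, 2 nitrogen, 2 oxygen, 2 sulfur; no ring), on an aromatic carbon, a reversed amide connection and a longer chain in place of the sulfonamide linker. Among the compounds with values here, no measured step covers this exact change; the one step that exists concerns chain length only and is small, so a change of the linker is expected to shift the read-out little, if at all, beyond the scatter. The expected step is a number 5.3 percentage points lower from compound 1 to compound 4 (within the scatter). For compound 4 the estimated value in this assay is 36%, with a range from 22% to 50%.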

Compound 4, a percentage reported as inhibition, at one concentration (the size of the read-out at that concentration, not a potency): 34.3%
The estimate for compound 4 lay 1.7 percentage points above the measured number; measured number inside the range.
By their numbers in this assay, from the lowest: compounds 3, 4, 2 and 1 (each within the scatter of the next, the first and the last beyond it).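

At this position, on an aromatic carbon of a six-membered aromatic ring of carbon only and para to a large group, replacing the sulfonamide-linked chain with the reversed amide-linked, longer chain gives a number 7 percentage points lower from compound 1 to compound 4 (within the scatter) in this assay. Compounds 2 and 3 differ only in chain length, whereas this step changes the linking group as well, and the read-out at this concentration does not tell the two linked chains apart. Because linker and chain length change together, the step cannot assign any part of the read-out to either one, and no available measurement bears on the result.

As far as these compounds go, it remains open how the sulfonamide linker behaves with a longer chain. Also open, from the compounds shown here alone, is whether the read-out holds when an amine replaces the terminal isothiocyanate on either linker.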